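Methoxy for methyl on the outer phenyl ring

This account rests on a few compounds, and the source may have more. Where it says the series, first, only, none or still open, it means among the compounds named here.

Working notes on the outer-ring variation of the shared core. Compound 2 `Cc1ccccc1-c1ccc(-c2coc(-c3ccccc3)n2)cc1` and compound 1 `Cc1nc(-c2ccc(-c3ccc(OCc4ccccc4)cc3)cc2)co1` have both been run in an assay on membranes from COS-7 cells for inhibition of Ectonucleotide pyrophosphatase/phosphodiesterase family member 1 (Homo sapiens), read by spectrophotometry, with a stated time of 35 min, tested at 100 uM; a lower number here means a stronger inhibitor, a higher number a weaker inhibitor. Compound 1 gives 1440 nM. Compound 2 gives 420 nM in this assay, the lowest of the two numbers in hand, with compound 1 the nearest and its number higher by more than the scatter. Going by the values given here, the two compounds differ in more than one place, so no single step is recorded between them; their two values alone are what is known.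

Compound 3 `COc1ccc(-c2ccc(-c3coc(-c4ccccc4)n3)cc2)cc1` is not yet measured. It derives from compound 2 by 4-methoxyphenyl in place of 2-methylphenyl on an aromatic carbon. Among the compounds with values here, no measured pair isolates this change, so the direction rests on nothing firmer than the two values above. The working expectation is a step of modest size a 1.4-fold higher number from compound 2 to compound 3 (0.15 log units; within the scatter), likely a slight weakening, though one that may well fall within the scatter. Compound 3 is thus expected to give about 600 nM in this assay, with a range from 200 nM to 2000 nM.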

Compound 3, half-maximal inhibitory concentration: 17200 nM
Beside the measured number, compound 3's estimate is 29-fold (1.46 log units) below it, outside the stated range (above it).
By their numbers in this assay, from the lowest: compound 2; then compound 1; then compound 3.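

In this assay this position on the outer phenyl ring proves highly sensitive to substitution: 4-methoxyphenyl in place of 2-methylphenyl on an aromatic carbon gives a 41-fold higher number from compound 2 to compound 3 (1.61 log units; beyond the scatter) and marks a large loss of inhibition. The earlier values came from two compounds differing in more than one place, so they could not tie any change in potency to this ring; this single change on the shared core now does, and the step lies well beyond the scatter. No measurement in hand accounts for the size of this step.

The step combines two differences, since the substituent changes from methyl to methoxy and its place on the ring changes too, so the compounds shown cannot separate the contribution of the group from that of its location. As far as these compounds go, it also remains open how far this ring tolerates other substituents, such as a fluorine, a hydroxyl, an amine or a carboxylic acid, and whether any of these at the place para to a large group would recover the potency of compound 2.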